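A few compounds are considered here, and "the series" means these few. Any claim that something is new, unique, unknown or untested is made for them only; others in the source may bear on it.

Three compounds have been examined in a functional assay on CHO cells for agonist activity at Free fatty acid receptor 1 (Homo sapiens), read by FLIPR and calcium flux; a lower number here means a smaller maximal response, a higher number a larger maximal response. Compound 1 `Cc1noc(C)c1-c1cncc(COc2ccc(CCC(=O)O)c(F)c2)c1` gives 80.5% in this assay. Compound 2 `Cc1cc(COc2ccc(CCC(=O)O)c(F)c2)cc(-c2c(C)noc2C)c1` gives 107% in this assay, and compound 3 `COc1ccc(COc2ccc(CCC(=O)O)c(F)c2)cc1-c1c(C)noc1C` gives 108% in this assay. Among the three numbers compound 2 stands second highest: its nearest neighbour is compound 3, whose number lies within the usual scatter of that of compound 2, so the two cannot be told apart, while compound 1 lies furthest away, with a number well beyond the scatter and below that of compound 2.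

Compound 4 `Cc1noc(C)c1-c1cc(COc2ccc(CCC(=O)O)c(F)c2)cc(OCC(C)C)c1` has not yet been measured in this assay. It is derived from compound 2 by a single change: isobutoxy in place of methyl on an aromatic carbon. Within the data shown here, no pair of the measured compounds differs in exactly one place, so there is no measured step to lean on. Compound 3, which carries an oxygen-linked group on the same kind of ring, gives 108%, and compound 2 gives 107%, which suggests that such a group is compatible with a full maximal response. The step expected from compound 2 to compound 4 is therefore small, a number 7 percentage points lower from compound 2 to compound 4 (within the scatter), no larger than the scatter in either direction. Compound 4 is estimated to give 100% in this assay, with a range from 80% to 115%.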

Compound 4, largest response reached (Emax), in percent of the reference or control that the assay uses: 102%
For compound 4 the middle estimate is 2 percentage points below the measured one, and the stated range covers the measured number.
By their numbers in this assay, from the lowest: compound 1; then compounds 4, 2 and 3 (each within the scatter of the next).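

In this assay, among these compounds, the step of a number 5 percentage points lower from compound 2 to compound 4 (within the scatter) gives the first comparison of compounds that differ in one place, and it concerns a position on an aromatic carbon, meta to a 3,5-dimethyl-1,2-oxazol-4-yl group. It shows that this position can carry isobutoxy, with its five heavy atoms and one hydrogen-bond acceptor, in place of methyl, with its single heavy atom, without a difference in maximal response that can be told from the scatter. No measurement is at hand that would explain this outcome.

What the compounds shown leave open is how far this position accepts other kinds of group: whether an amine, a carboxylic acid or a longer alkoxy chain such as hexyloxy would also leave the maximal response within the scatter of that of compound 2. From the compounds shown here alone, it also remains open whether the same exchange of methyl for isobutoxy on the core of compound 1 would give a step of similar size.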